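The compounds below may be only part of what the source reports. "The series", "measured", "known", "first", "only" and "open" are said of these compounds alone.

Measured so far in a functional assay on SW-620 cells (Homo sapiens) for inhibition, read by MTT assay, with a stated time of 4 days; a higher number here means a weaker inhibitor, a lower number a stronger inhibitor:
Compound 1 `COc1cc(NC(C)CCCNC(=O)Nc2ccc(Cl)c(C(F)(F)F)c2)c2ncccc2c1` gives 23000 nM.
Compound 2 `COc1cc(NC(C)CCCNC(=O)NNC(=O)NCCCCCO)c2ncccc2c1` gives > 100000 nM, which is a limit of the assay and not a number.
Compound 3 `COc1cc(NC(C)CCCNC(=O)NNC(=O)NCCO)c2ncccc2c1` gives > 100000 nM, again a limit of the assay rather than a number.

For the measured compounds named here, compound 3 thus stands at the top limit of this assay: two of the three values shown sit there (the limit of > 100000 nM in this assay, at which 2 of the 3 values shown sit), and compound 1 is the only compound with a number. The step of an at least 4.3-fold higher number from compound 1 to compound 3 (0.63 log units; beyond the scatter) shows that putting ((2-hydroxyethyl)carbamoyl)amino in place of 4-chloro-3-(trifluoromethyl)phenyl weakened inhibition beyond the scatter, reaching the limit. The step that the two limits leave unreadable from compound 2 to compound 3 cannot be read; both of its values are limits.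

Compound 4 `COc1cc(NC(C)CCCNC(=O)NNC(=O)NC(CO)(CO)CO)c2ncccc2c1` has not yet been tested. It differs from compound 3 in one place: 2-hydroxy-1,1-bis(hydroxymethyl)ethyl in place of 2-hydroxyethyl on an amide-type nitrogen. So the step from compound 3 to compound 4 exchanges the 2-hydroxyethyl group for the 2-hydroxy-1,1-bis(hydroxymethyl)ethyl group in a compound already at the limit. Going by the values given here, the only readable step, an at least 4.3-fold higher number from compound 1 to compound 3 (0.63 log units; beyond the scatter), ran toward weaker inhibition, and nothing among the measured compounds points back toward a stronger inhibitor. Compound 4 is therefore expected to remain at the limit, giving a step that the limit leaves unreadable from compound 3 to compound 4, a step that would again not be readable. The estimate for compound 4 is 150000 nM, with a range from 50000 nM to 500000 nM.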

Compound 4, half-maximal inhibitory concentration: > 100000 nM
Compound 4: only a limit was reported (the forecaster's own chance of this, stated with the estimate: 85%); the middle value is on the limit's open side.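

In this assay, compound 4 gives > 100000 nM, which is a limit of the assay and not a number. Placing 2-hydroxy-1,1-bis(hydroxymethyl)ethyl on the amide-type nitrogen, a branched group with more hydrogen-bond donors and acceptors than 2-hydroxyethyl, did not bring the series back to a readable number, so the limit now holds for one more group at this position: the limit of > 100000 nM in this assay, at which 3 of the 4 values shown sit.
For the compounds shown here, the only new step that can be read is an at least 4.3-fold higher number from compound 1 to compound 4 (0.63 log units; beyond the scatter), with ((2-hydroxy-1,1-bis(hydroxymethyl)ethyl)carbamoyl)amino in place of 4-chloro-3-(trifluoromethyl)phenyl; the steps among the three compounds at the limit cannot be read, so nothing ranks their groups against one another.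

That readable step exchanges the whole substituent at once, which leaves open whether the change in the linking carbamoyl amino unit or the loss of the 4-chloro-3-(trifluoromethyl)phenyl ring matters more. As far as these compounds go, it also remains open whether an amine or a carboxylic acid in place of the hydroxy groups, or an aromatic ring such as phenyl on the same amide-type nitrogen, would give a number inside the range of this assay.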